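Benzoxaborole propanamides: aryl amide variation

A few compounds are considered here, and "the series" means these few. Any claim that something is new, unique, unknown or untested is made for them only; others in the source may bear on it.

Compound 1 `O=C(CCc1cccc2c1B(O)OC2)Nc1nccs1` gives > 100000 nM in a functional assay on MDA-MB-231 cells (Homo sapiens) for antiproliferative activity, read by MTT assay, with a stated time of 72 h (on this read-out higher numbers stand for weaker inhibition and lower numbers for stronger inhibition), a limit of the assay rather than a number; this is the limit noted in the limit of > 100000 nM in this assay, at which 1 of the 2 values shown sits. Among the compounds with values here, compound 2 `C#Cc1cccc(NC(=O)CCc2cccc3c2B(O)OC3)c1` gives 1600 nM in this assay and so carries the only number. Compound 3 `O=C(CCc1cccc2c1B(O)OC2)Nc1cccc(-c2ccc(C(F)(F)F)cc2)c1` is not yet measured; it differs from compound 2 by 4-(trifluoromethyl)phenyl in place of ethynyl on an aromatic carbon. Within the data shown here, no measured step between related compounds exists to anchor the size of this change. A modest gain in inhibition, somewhat beyond the scatter, is expected, as a 2.0-fold lower number from compound 2 to compound 3 (0.30 log units; within the scatter). Compound 3 is estimated at 800 nM, within 200 nM to 4000 nM.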

Compound 3, half-maximal inhibitory concentration: 510 nM
Compound 3: middle estimate off by 1.6-fold (0.20 log units), on the high side; the range from low to high includes it.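

In this assay the position on an aromatic carbon, meta to a large group, accepts 4-(trifluoromethyl)phenyl, with 10 heavy atoms and one six-membered aromatic ring, in place of ethynyl, with 2 heavy atoms. Within the data shown here, the exchange gives a 3.1-fold lower number from compound 2 to compound 3 (0.50 log units; beyond the scatter) and is the first measured step, so inhibition here survives a much larger group. Nothing measured here bears on the reason for this step.

Open, on these data alone, is whether the added ring alone carries the gain or the trifluoromethyl contributes. Plain phenyl, or a phenyl bearing an amine or a carboxylic acid, would separate the two.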